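The compounds below may be only part of what the source reports. "The series", "measured", "known", "first", "only" and "open" are said of these compounds alone.

Of the compounds shown here, two have been measured in an assay for inhibition of cholesterol 24-hydroxylase (Homo sapiens), using NADPH, with stated times of 15 min and 5 min (on this read-out lower numbers stand for stronger inhibition and higher numbers for weaker inhibition), so far. Compound 1 `Cc1ccccc1C1=NN(C(=O)c2ccncc2)C(C)(C)C1` gives 60 nM in this assay. Compound 2 `O=C(c1cc(Cl)ccc1-c1ccncc1)N1CCC(O)(Cc2ccccc2)CC1` gives 2.4 nM in this assay, the lowest of the two numbers; the gap to compound 1 lies well beyond the usual scatter of repeated measurements, so compound 2 counts as the stronger inhibitor of the pair.

Compound 3 `COc1ccc(-c2ccncc2)c(C(=O)N2CCC(O)(Cc3ccccc3)CC2)c1` is the next compound to be measured. It differs from compound 2 in one place: methoxy in place of chloro on an aromatic carbon. Among the compounds with values here, no single-point step between two measured compounds is available to guide the estimate, so the expectation rests on the change itself and on the standing of compound 2.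

A methoxy in place of a chloro on the same aromatic carbon is a small exchange, and the step from compound 2 to compound 3 is expected to be a 1.7-fold higher number from compound 2 to compound 3 (0.22 log units; within the scatter), which would leave the result close to, or only slightly above, the number for compound 2. Compound 3 is therefore estimated at 4 nM in this assay, with a likely range from 1.5 nM to 12 nM.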

Compound 3, half-maximal inhibitory concentration: 4.7 nM
Compound 3: the middle estimate sits 1.2-fold (0.07 log units) below what was measured; the range from low to high includes it.
By their numbers in this assay, from the lowest: compounds 2 and 3 (each within the scatter of the next); then compound 1.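

Within the data shown here, compound 3 gives the first single-place step in this set: in this assay, methoxy in place of chloro on this aromatic carbon, meta to a large group and para to a pyridin-4-yl group, gives a 2.0-fold higher number from compound 2 to compound 3 (0.29 log units; within the scatter). The two compounds therefore cannot be told apart in this assay, even though the entering group has 2 heavy atoms against 1 for chloro and brings a hydrogen-bond acceptor that chloro lacks. No measurement is available that would explain this result.

With only chloro and methoxy seen at this position, the compounds shown leave open whether a longer chain such as ethoxy, an amine or a carboxylic acid on the same aromatic carbon would keep the number in the same range. They also leave open how much the pyridin-4-yl group and the rest of the shared core contribute, since neither changes between compound 2 and compound 3.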